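This account rests on a few compounds, and the source may have more. Where it says the series, first, only, none or still open, it means among the compounds named here.

Measured in an assay on CHO cells for displacement of a labelled ligand from adenosine receptor A3 (Homo sapiens); on this read-out lower numbers stand for stronger inhibition and higher numbers for weaker inhibition:
compound 1 `CNc1nc(Cl)nc2c1ncn2[C@@H]1O[C@H](C(=O)NCC2CC2)[C@@H](O)[C@H]1O` gives 1.1 nM
compound 2 `O=C(NCC1CC1)[C@H]1O[C@@H](n2cnc3c(NCc4cccc(I)c4)nc(Cl)nc32)[C@H](O)[C@@H]1O` gives 3.63 nM

Going by the values given here, compound 2 holds the higher of the two numbers in this assay; the only measured step in the set is a 3.3-fold higher number from compound 1 to compound 2 (0.52 log units; beyond the scatter). Compound 3 `O=C(NCc1cccc(Cl)c1)[C@H]1O[C@@H](n2cnc3c(NCc4cccc(I)c4)nc(Cl)nc32)[C@H](O)[C@@H]1O` is not yet measured. It differs from compound 2 by 3-chlorophenyl in place of cyclopropyl on a saturated chain carbon bound to an amide-type nitrogen. Among the compounds with values here, the one measured step concerns a different place, a saturated chain carbon bound to a nitrogen on an aromatic ring, and leaves the amide side untouched, so no measured step bears on the change from compound 2 to compound 3. Neither direction nor size can be read from the set, and the data give no anchor for this position. The step of a 2.2-fold higher number from compound 2 to compound 3 (0.34 log units; beyond the scatter) is therefore estimated as a modest rise, with a wide range on either side. For compound 3 the expected value in this assay is 8 nM, range 2 nM to 35 nM.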

Compound 3, inhibition constant: 309 nM
Estimate against measurement, compound 3: 39-fold (1.59 log units) below; measured number outside the range, above it.
By their numbers in this assay, from the lowest: compound 1; then compound 2; then compound 3.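

The amide side of the series is not a silent position: in this assay, 3-chlorophenyl in place of cyclopropyl on a saturated chain carbon bound to an amide-type nitrogen gives an 85-fold higher number from compound 2 to compound 3 (1.93 log units; beyond the scatter) as a large step. The earlier change, a 3.3-fold higher number from compound 1 to compound 2 (0.52 log units; beyond the scatter), was only modest, so among the changes shown this position is the more sensitive one. Nothing on hand gives a reason for the size of this step.

From the compounds shown here alone, it remains open whether the rise follows the aromatic ring, the chlorine or the larger group as a whole, and a plain benzyl or a longer alkyl chain on the amide-type nitrogen would help to separate these. Also open, going by these compounds, is whether the same change would cost as much in compound 1, which lacks the 3-iodophenyl group.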